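This account rests on a few compounds, and the source may have more. Where it says the series, first, only, none or still open, it means among the compounds named here.

Measured so far:
compound 1, `CCCc1cc(C(C)=O)c(O)cc1OCCCCC#N`, giving 84%;
compound 2, `CCc1cc(C(C)=O)c(O)cc1OCCCCCCCC(C)(C)C#N`, giving 66%.

In an assay on isolated protein for inhibition of leukotriene B4 receptor 1 (Homo sapiens), tested at 10 uM (a higher number here means more inhibition at the concentration tested (going by the name of the read-out), a lower number less inhibition), compound 2 stands lowest of the two numbers, with compound 1 the nearer one, a gap beyond the usual scatter. Compound 3, `CCc1cc(C(C)=O)c(O)cc1OCCCCCCS(C)(=O)=O`, is not yet measured. It differs from compound 2 in one place: methylsulfonyl in place of 2-cyano-2-methylpropyl on a saturated chain carbon, six bonds along the chain from an oxygen on an aromatic ring. Within the data shown here, nothing measured so far covers a methylsulfonyl tail, so the step is uncertain; a small change in this assay is expected, downward if anything, plausibly within the scatter, as a number 6 percentage points lower from compound 2 to compound 3 (within the scatter). Compound 3 is therefore estimated at 60%, likely between 30% and 85%.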

Compound 3, a percentage reported as inhibition, at one concentration (the size of the read-out at that concentration, not a potency): 99%
Compound 3: middle estimate off by 39 percentage points, on the low side, outside the stated range (above it).
By their numbers in this assay, from the lowest: compound 2; then compound 1; then compound 3.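

In this assay, the end of the chain at this place has a large influence on the read-out: methylsulfonyl in place of 2-cyano-2-methylpropyl gives a number 33 percentage points higher from compound 2 to compound 3 (beyond the scatter). A nitrile is therefore not needed for high inhibition at the concentration tested. No measurement available here explains the size of this step.

Still open, on these data alone, is whether a carboxylic acid, an amide or an amine at the same chain carbon would match methylsulfonyl. Also open, as far as these compounds go, is whether a longer chain carrying methylsulfonyl would perform as well.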